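Pyridin-2-yl in Place of the Pyrazolyl Group

The source may hold more compounds than are shown below. What is called first, only, known or untested is meant among the compounds shown, and "the series" means these compounds.

Going by the values given here, compound 2 `Cc1nn(-c2ccccc2)cc1/C=N/Nc1nc(Nc2ccccc2)nc(Nc2ccc(S(N)(=O)=O)cc2)n1` gives 2220 nM in a functional assay on PC-3 cells (Homo sapiens) for inhibition, read by sulforhodamine B assay, with a stated time of 48 h (a higher number here means a weaker inhibitor of growth, a lower number a stronger inhibitor of growth), which is the lowest of the two numbers measured so far; its nearest neighbour is compound 1 `NS(=O)(=O)c1ccc(Nc2nc(N/N=C/c3ccc(C(F)(F)F)cc3)nc(Nc3ccccc3)n2)cc1`, which gives 2800 nM, and the step of a 1.3-fold lower number from compound 1 to compound 2 (0.10 log units; within the scatter) lies within the scatter, so no real order between the two can be claimed. Compound 3 `NS(=O)(=O)c1ccc(Nc2nc(N/N=C/c3ccccn3)nc(Nc3ccccc3)n2)cc1` differs from compound 2 in one place: pyridin-2-yl in place of 3-methyl-1-phenyl-1H-pyrazol-4-yl on a carbon with a double bond to nitrogen. Among the compounds with values here, the only measured step that bears on this position, a 1.3-fold lower number from compound 1 to compound 2 (0.10 log units; within the scatter), also exchanged the group on the same carbon and stayed within the scatter. With a single comparison of that kind to go on, the expectation for compound 3 is a step of about a 1.1-fold higher number from compound 2 to compound 3 (0.05 log units; within the scatter), that is, no change beyond the scatter. Compound 3 is therefore expected to give 2500 nM, within a range of 1000 nM to 6000 nM.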

Compound 3, concentration for 50% growth inhibition: 690 nM
For compound 3 the middle estimate is 3.6-fold (0.56 log units) above the measured one; the whole stated range lies above it.
By their numbers in this assay, from the lowest: compound 3; then compounds 2 and 1 (each within the scatter of the next).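

In this assay, the group on the carbon with a double bond to nitrogen can clearly make a difference: pyridin-2-yl gives a 3.2-fold lower number from compound 2 to compound 3 (0.51 log units; beyond the scatter) and a 4.1-fold lower number from compound 1 to compound 3 (0.61 log units; beyond the scatter), both beyond the scatter, whereas the earlier exchange at this place stayed within it. The change from compound 2 to compound 3 replaces 12 heavy atoms and two rings with 6 heavy atoms and one ring, so a smaller group and a different ring change together, and this pair cannot separate the two. No measurement here explains why compound 3 inhibits growth more strongly.

The compounds shown leave open whether the ring nitrogen of pyridin-2-yl matters, a question that plain phenyl or pyridin-3-yl on the same carbon could address. As far as these compounds go, how a small open-chain group, such as methyl or a short chain ending in an amine, would fare at this place also remains open.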